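A hydroxy added to the dimethylphenyl ring of compound 2

The source may hold more compounds than are shown below. What is called first, only, known or untested is meant among the compounds shown, and "the series" means these compounds.

Compound 1 `COc1cccc(/C=C2\CCc3cc(OC)c(OC)cc3C2=O)c1` gives 5000 nM in a functional assay on Jurkat cells (Homo sapiens) for antiproliferative activity, read by MTT assay; a lower number here means a stronger inhibitor, a higher number a weaker inhibitor.
Compound 2 `COc1cc2c(cc1OC)C(=O)/C(=C/c1cc(C)cc(C)c1)CC2` gives 4000 nM.
Compound 3 `COc1cc2c(cc1OC)C(=O)/C(=C/c1cc(Cl)cc(Cl)c1)CC2` gives 7000 nM.

Compound 2 holds the smallest number of the three, yet every step among them lies within the scatter: a 1.3-fold lower number from compound 1 to compound 2 (0.10 log units; within the scatter), a 1.8-fold higher number from compound 2 to compound 3 (0.24 log units; within the scatter), and a 1.4-fold higher number from compound 1 to compound 3 (0.15 log units; within the scatter). Compound 4 `COc1cc2c(cc1OC)C(=O)/C(=C/c1cc(C)c(O)c(C)c1)CC2` is compound 2 with hydroxy in place of hydrogen on an aromatic carbon. For the measured compounds named here, none of the measured steps bears on this change; each of them exchanges the whole aryl group, and none moved the number beyond the scatter. Going by the values given here, no measured step therefore points to a large shift. A modest lowering is expected for compound 4, estimated as a 1.6-fold lower number from compound 2 to compound 4 (0.20 log units; within the scatter). In this assay compound 4 is estimated at 2500 nM, with a range from 600 nM to 10000 nM.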

Compound 4, half-maximal inhibitory concentration: 4800 nM
Compound 4: middle estimate off by 1.9-fold (0.28 log units), on the low side; measured number inside the range.
By their numbers in this assay, from the lowest: compounds 2, 4, 1 and 3 (each within the scatter of the next).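

Unlike the earlier steps, which exchange the whole aryl group, this one adds a single hydroxy to it, on the aromatic carbon ortho to two methyl groups and para to a large group, and gives [ a 1.2-fold higher number from compound 2 to compound 4 (0.08 log units; within the scatter) ]. The entering hydrogen-bond donor and acceptor therefore leave compound 4 inseparable from compound 2 at this position. Nothing available explains this result.

From the compounds shown here alone, whether a methoxy, an amine or a carboxylic acid at this position would read the same remains open. So does whether the hydroxy would read the same without the two methyl groups.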